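From nitro to amino on compound 3

The source may hold more compounds than are shown below. What is called first, only, known or untested is meant among the compounds shown, and "the series" means these compounds.

In a functional assay on HCT-116 cells (Homo sapiens) for inhibition (a lower number here means a stronger inhibitor, a higher number a weaker inhibitor), compound 3 `COc1ccc(/C=C\c2ccc3ccccc3c2)cc1[N+](=O)[O-]` gives only a limit, > 20000 nM, and not a number. Compound 2 `COc1ccc(/C=C/c2ccc3ccccc3c2)cc1[N+](=O)[O-]`, which has the same atoms and bonds, also gives only a limit, > 5000 nM, and not a number. Compound 1 `CN(C)c1ccc(/C=C/c2ccc3ccccc3c2)cc1`, which has no nitro group, gives a true number of 3660 nM in this assay on the same scale.

Compound 4 `COc1ccc(/C=C\c2ccc3ccccc3c2)cc1N` differs from compound 3 in one place: amino in place of nitro on an aromatic carbon, which is amino in place of nitro on an aromatic carbon, ortho to a methoxy group. Going by the values given here, the one measured step, a step that the two limits leave unreadable from compound 2 to compound 3, has no readable size and concerns (the fact that compounds 2 and 3 differ only in the configuration as drawn), so it offers no guide to swapping nitro for amino. Among the compounds with values here, the nearest guide is compound 1 at 3660 nM, the only measured compound without nitro that has a number, so a move towards stronger inhibition is expected, though on thin evidence. The expected change is an at least 10-fold lower number from compound 3 to compound 4 (1.00 log units; beyond the scatter) on this estimate. For compound 4 the estimated value is 2000 nM, with an expected range from 200 nM to 15000 nM for the measurement.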

Compound 4, half-maximal inhibitory concentration: 360 nM
Estimate against measurement, compound 4: 5.6-fold (0.74 log units) above, and the stated range covers the measured number.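

In this assay, putting amino in place of nitro on this aromatic carbon, ortho to a methoxy group, gives an at least 55-fold lower number from compound 3 to compound 4 (1.74 log units; beyond the scatter), so this position responds strongly to the change. Going by these compounds alone, compound 3 has only a limit, > 20000 nM, and not a number, whereas compound 4 gives the first true number among the compounds with the double bond drawn Z, 360 nM. Nothing shown here explains why the swap has so large an effect.

On these data alone, the step between the two nitro compounds cannot be read, so whether amino would give a similar result with the double bond drawn E remains open. As far as these compounds go, it is also open how other groups at this carbon, such as a hydroxyl or an acetamide, would compare with amino.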